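A Fluoro-to-Chloro Swap on Two Different Cores

The source may report more compounds than this note shows. Statements on the series, on what has been measured and on what is new or still open speak of the compounds shown alone.

Compound 1 `C#CCNC1CCc2c(SCc3ccc(F)cc3)cccc21` and compound 2 `C#CCNC1CCc2c(SCc3ccc(Cl)cc3)cccc21` share a core and differ only in one halogen. In an assay on cells for inhibition of Amine oxidase [flavin-containing] B (Homo sapiens), read by fluorescence and Amplex Red, with stated times of 30 min and 15 min (on this read-out higher numbers stand for weaker inhibition and lower numbers for stronger inhibition), compound 1 gives 240 nM, and compound 2 gives 180 nM. The change between them, (chloro in place of fluoro on an aromatic carbon), gave a 1.3-fold lower number from compound 1 to compound 2 (0.12 log units; within the scatter).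

Compound 3 `C#CCNC1CCc2c(OCCc3cc(NC(=O)c4ccc(F)cc4)ccc3Cl)cccc21` carries a much larger ether tail on the same bicyclic amine. Its value in this assay, 5100 nM, is the highest of the three numbers; compound 1 gives a lower number and compound 2 lower still. The difference between the core of compound 3 and the core of compound 1 is not broken down here.

Compound 4 `C#CCNC1CCc2c(OCCc3cc(NC(=O)c4ccc(Cl)cc4)ccc3Cl)cccc21` is the not yet measured partner of compound 3. The change from compound 3 to compound 4, (chloro in place of fluoro on an aromatic carbon), is the same change that turned compound 1 into compound 2, made at the same kind of place on the terminal ring of the amide. Within the data shown here, since that earlier change stayed within the scatter, the step expected from compound 3 to compound 4 in this assay is also small, a 1.3-fold lower number from compound 3 to compound 4 (0.11 log units; within the scatter), resting on the single precedent of compound 1 to compound 2 with its a 1.3-fold lower number from compound 1 to compound 2 (0.12 log units; within the scatter) and on the fact that compound 3 already gives 5100 nM. Compound 4 is therefore expected to give about 4000 nM, most likely between 1800 nM and 9000 nM.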

Compound 4, half-maximal inhibitory concentration: > 20000 nM
Compound 4 was reported as a limit; the forecaster's own chance of this, stated with the estimate: 5%; middle value at least 5.0-fold (0.69 log units) away from the limit.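

In this assay, chloro in place of fluoro on the terminal ring of the amide gives an at least 3.9-fold higher number from compound 3 to compound 4 (0.59 log units; beyond the scatter). Set beside the earlier step, this shows that the result of the swap on one core does not carry over to the other, so the small step on the first core was a poor guide to the second: the same change on two cores in this assay, a 1.3-fold lower number (0.12 log units; within the scatter) from compound 1 to compound 2 and an at least 3.9-fold higher number (0.59 log units; beyond the scatter) from compound 3 to compound 4, at least 5.2-fold (0.71 log units) apart, beyond the scatter of two such steps Compound 4 is reported only as a limit of the assay, > 20000 nM, so the full size of its step remains unknown, and with a single pair on each core the data do not show which part of the larger ether tail goes with the different outcome: the limit of > 20000 nM in this assay, at which 1 of the 4 values shown sits.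

From the compounds shown here alone, it remains open whether the sensitivity to the halogen belongs to the amide-bearing tail as a whole or only to this particular pair of compounds. A bromo or a plain hydrogen in the same place on the terminal ring would test how the series responds to other substituents there, and a longer chain in the ether tail, or an amine in place of the amide, would test how far the gap between the two cores depends on the tail.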